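The source may hold more compounds than are shown below. What is called first, only, known or untested is meant among the compounds shown, and "the series" means these compounds.

Working notes on the series. In a functional assay on HCC1806 cells (Homo sapiens) for inhibition, read by sulforhodamine B assay, tested at 10 uM (a lower number here means less inhibition, a higher number more inhibition at the concentration tested (going by the name of the read-out)), the three measured compounds of this pyrazoline-type set all come out on the negative side: compound 1 `CN(C)c1ccc(C2CC(c3ccc(-n4ccnc4)cc3)=NN2)cc1` gives -20.9%, compound 2 `COC(=O)CC(=O)N1N=C(c2ccc(N3CCN(C)CC3)cc2)CC1c1ccc(N(C)C)cc1` gives -8.3% and compound 3 `COC(=O)CC(=O)N1N=C(c2ccc(-n3cncn3)cc2)CC1c1ccc(N(C)C)cc1` gives -7.8%. Compound 3 stands highest of the three, with compound 2 nearest and compound 1 furthest; the step of a number 0.5 percentage points higher from compound 2 to compound 3 (within the scatter) is within the scatter, so the exchange of 1H-1,2,4-triazol-1-yl for 4-methylpiperazin-1-yl on the aromatic carbon did nothing measurable, while the gap to compound 1 lies beyond the scatter.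

Compound 4 `CN(C)c1ccc(C2CC(c3ccc(-n4cncn4)cc3)=NN2S(=O)(=O)c2ccc(F)cc2)cc1` differs from compound 3 as follows: (4-fluorophenyl)sulfonyl in place of ((methoxycarbonyl)methyl)carbonyl on an amine nitrogen in a ring. For the measured compounds named here, no measured step touches the amine nitrogen in the ring; the only step in hand, that from compound 2 to compound 3, concerns the aromatic carbon and was flat. Compound 1, which carries a hydrogen on that ring nitrogen and a different aryl group, gives the lowest value, but with two changes at once it cannot be read as a step. For compound 4 the expectation is therefore no movement beyond the scatter, a step of a number 2.8 percentage points higher from compound 3 to compound 4 (within the scatter), with the estimated value -5% in the range -25% to 15%.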

Compound 4, a percentage reported as inhibition, at one concentration (the size of the read-out at that concentration, not a potency): 24.1%
Beside the measured number, compound 4's estimate is 29.1 percentage points below it, and the stated range ends below it.
By their numbers in this assay, from the lowest: compound 1; then compounds 2 and 3 (each within the scatter of the next); then compound 4.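

For the compounds shown here, the amine nitrogen in the ring is the first position where a single change moves the number beyond the scatter: in this assay, (4-fluorophenyl)sulfonyl in place of ((methoxycarbonyl)methyl)carbonyl gives a number 31.9 percentage points higher from compound 3 to compound 4 (beyond the scatter), whereas the one earlier step, on the aromatic carbon, was flat. The entering group carries a six-membered aromatic ring of carbon only and the leaving group has no ring, but this single step cannot separate the contribution of the sulfonyl link, the aromatic ring or the fluorine. No measurement at hand accounts for the size of the step.

Open, from the compounds shown here alone, is whether a methanesulfonyl group, an unsubstituted phenylsulfonyl group or a benzoyl group on the same nitrogen would give a similar number. Also open, going by these compounds, is whether the step would carry over with 4-methylpiperazin-1-yl in place of 1H-1,2,4-triazol-1-yl on the aromatic carbon.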